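A few compounds are considered here, and "the series" means these few. Any claim that something is new, unique, unknown or untested is made for them only; others in the source may bear on it.

Measured so far:
compound 1 `CN1CCN(c2nc3cc([N+](=O)[O-])ccc3o2)CC1`, which in a functional assay on ileum (strain Hartley) for agonist activity at 5-hydroxytryptamine receptor 3A (Cavia porcellus) (a higher number here means a more potent compound, by a factor of ten per unit of this negative logarithm, a lower number a less potent compound), gives 6.1
compound 2 `Cc1cc(C)c2oc(N3CCN(C)CC3)nc2c1`, which in this assay gives 6.32

Compound 1 stands at the lower of the two numbers, and compound 2 lies within the scatter of it, so the two cannot be ordered on these figures. Both carry the same shared core, with the methylpiperazine attached in the same way, and differ only in what sits on the six-membered aromatic ring of carbon only.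

The step considered here leads from compound 1 to compound 3 `COc1ccc2oc(N3CCN(C)CC3)nc2c1`, which has not yet been measured in this assay. The change is methoxy in place of nitro on an aromatic carbon. For the measured compounds named here, no step between measured compounds with a comparable exchange is available, so the expected effect can only be read from the closeness of compound 1 and compound 2, which suggests that changes on this ring are tolerated in this assay. The expected step from compound 1 to compound 3 is therefore a number 0.10 log units higher from compound 1 to compound 3 (within the scatter), that is none beyond the scatter. For compound 3 the estimate in this assay is 6.2, with a range from 5.6 to 6.8.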

Compound 3, negative logarithm of the half-maximal effective concentration: 4.78
Beside the measured number, compound 3's estimate is 1.42 log units above it, outside the stated range (below it).
By their numbers in this assay, from the lowest: compound 3; then compounds 1 and 2 (each within the scatter of the next).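

In this assay, methoxy in place of nitro on this aromatic carbon, meta to a fused ring and para to a fused ring, gives a number 1.32 log units lower from compound 1 to compound 3 (beyond the scatter). The values of compound 1 and compound 2 lie within the scatter of each other and suggested that the ring tolerates changes, whereas this single exchange shows that the group at this position can matter a great deal in this assay. The data shown offer no measurement that bears on why this step is so large.

As far as these compounds go, this one exchange cannot separate the departure of nitro from the arrival of methoxy, so it remains open whether plain hydrogen, a nitrile or an amine on the same aromatic carbon would stay close to compound 1 or fall nearer to compound 3. From the compounds shown here alone, it also remains open whether the same exchange would produce a step of similar size at another carbon of this ring.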